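The source may hold more compounds than are shown below. What is called first, only, known or untested is meant among the compounds shown, and "the series" means these compounds.

Among the compounds with values here, compound 1 `C#Cc1cccc(Nc2ncnc3cc(OC)c(OCCCCC(=O)Nc4ccc(S(N)(=O)=O)cc4)cc23)c1` is the one member of the series with a proper number in a functional assay on A549 cells (Homo sapiens) for antiproliferative activity, read by MTT assay, with a stated time of 72 h; a lower number here means a stronger inhibitor, a higher number a weaker inhibitor: compound 1 gives 7720 nM. Compound 2 `COc1cc2ncnc(Nc3ccc(Br)cc3)c2cc1OCCCCC(=O)Nc1ccc(S(N)(=O)=O)cc1` reaches only the limit of the assay, giving > 40000 nM. Compound 3 `COc1ccc(Nc2ncnc3cc(OC)c(OCCCCC(=O)Nc4ccc(S(N)(=O)=O)cc4)cc23)cc1OC` likewise reaches only the limit, giving > 40000 nM. Both departures from compound 1 therefore read as losses: an at least 5.1-fold higher number from compound 1 to compound 2 (0.71 log units; beyond the scatter), and an at least 5.1-fold higher number from compound 1 to compound 3 (0.71 log units; beyond the scatter). The step that the two limits leave unreadable from compound 2 to compound 3 cannot be sized because of the limit of > 40000 nM in this assay, at which 2 of the 3 values shown sit. Compound 4 `CCc1ccc(Nc2ncnc3cc(OC)c(OCCCCC(=O)Nc4ccc(S(N)(=O)=O)cc4)cc23)cc1` differs from compound 1 by 4-ethylphenyl in place of 3-ethynylphenyl on a nitrogen on an aromatic ring. Both measured exchanges of the 3-ethynylphenyl group weakened activity at least modestly, so a loss of similar size is expected here, with a real chance that compound 4 also stops at the limit; the expected step is a 3.9-fold higher number from compound 1 to compound 4 (0.59 log units; beyond the scatter). Compound 4 is thus estimated at 30000 nM, within 10000 nM to 80000 nM.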

Compound 4, half-maximal inhibitory concentration: 12100 nM
Estimate against measurement, compound 4: 2.5-fold (0.39 log units) above; low and high end bracket the measured number.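

Within the data shown here, the 3-ethynylphenyl group is not the only group on this nitrogen that keeps a measurable number: changing to 4-ethylphenyl, with its count of 8 heavy atoms unchanged, gives a 1.6-fold higher number from compound 1 to compound 4 (0.20 log units; within the scatter). Leaving 3-ethynylphenyl therefore does not by itself bring a loss, and compound 4 separates from the other two exchanges, with an at least 3.3-fold lower number from compound 3 to compound 4 (0.51 log units; beyond the scatter) and an at least 3.3-fold lower number from compound 2 to compound 4 (0.51 log units; beyond the scatter). Both of these steps start from a limit of the assay, not a number: the limit of > 40000 nM in this assay, at which 2 of the 4 values shown sit.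

Open, going by these compounds, is how 3-ethylphenyl or 4-ethynylphenyl would read on this nitrogen, which would separate the identity of the group from its place on the ring.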